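The source may report more compounds than this note shows. Statements on the series, on what has been measured and on what is new or still open speak of the compounds shown alone.

Measured so far in a functional assay on SF-539 cells (Homo sapiens) for inhibition, read by sulforhodamine B assay, with a stated time of 48 h; on this read-out lower numbers stand for stronger inhibition of growth and higher numbers for weaker inhibition of growth:
compound 1 `COc1cc(-c2nn(-c3cccc(NC(=O)c4ccc(Cl)c(C(F)(F)F)c4)c3)cc2-c2ccncc2)ccc1Cl` gives 4130 nM;
compound 2 `O=C(Nc1cccc(-n2cc(-c3ccncc3)c(-c3ccc(Cl)c(O)c3)n2)c1)Nc1cc(C(F)(F)F)cc(C(F)(F)F)c1` gives 765 nM;
compound 3 `COc1cc(-c2nn(-c3cccc(NC(=O)Nc4cccc(C(F)(F)F)c4)c3)cc2-c2ccncc2)ccc1Cl` gives 890 nM.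

Compound 3 stands second highest of the three numbers. Against compound 2 it lies within the scatter, while the one single-place step, a 4.6-fold lower number from compound 1 to compound 3 (0.67 log units; beyond the scatter), is beyond the scatter. Compound 4 `COc1cc(-c2nn(-c3cccc(NC(=O)Nc4cc(C(F)(F)F)cc(C(F)(F)F)c4)c3)cc2-c2ccncc2)ccc1Cl` differs from compound 3 in one place: trifluoromethyl in place of hydrogen on an aromatic carbon. Within the data shown here, no measured step bears directly on this change. Among the measured compounds shown here, compound 2 already carries two trifluoromethyl groups on that ring, yet it also differs from compound 3 in a second place, so its value shows only that such a group sits alongside a similar number. The expected step of a 1.3-fold lower number from compound 3 to compound 4 (0.10 log units; within the scatter) is therefore small, probably within the scatter. Compound 4 is estimated at 700 nM, with a range from 300 nM to 1600 nM.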

Compound 4, concentration for 50% growth inhibition: 829 nM
Compound 4: the middle estimate sits 1.2-fold (0.07 log units) below what was measured, and the stated range covers the measured number.
By their numbers in this assay, from the lowest: compounds 2, 4 and 3 (each within the scatter of the next); then compound 1.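

In this assay the new step is a 1.1-fold lower number from compound 3 to compound 4 (0.03 log units; within the scatter), so this spot on the six-membered aromatic ring takes a trifluoromethyl in place of hydrogen with no change that can be read. The step for methyl in place of hydrogen on the oxygen is a 1.1-fold higher number from compound 2 to compound 4 (0.03 log units; within the scatter), so that swap also leaves no readable change. Nothing measured here explains either result.

Going by these compounds, whether an amine or a carboxylic acid at the same spot would also leave the number in place remains open. So does the effect of a longer chain on that oxygen.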